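Shortening the piperazine-bearing chain by one bond

The source may report more compounds than this note shows. Statements on the series, on what has been measured and on what is new or still open speak of the compounds shown alone.

Compound 1 `COc1cc2oc(-c3ccccc3)cc(=O)c2c2c1OCCCCO2` gives only a limit in a functional assay on BCG823 cells (Homo sapiens) for antiproliferative activity, read by MTT assay, with a stated time of 48 h (on this read-out lower numbers stand for stronger inhibition and higher numbers for weaker inhibition), > 100000 nM. Compound 2 `COc1cc2oc(-c3ccccc3)cc(=O)c2c(O)c1OCCCCN1CCN(C)CC1` stands at 53500 nM in this assay, and the nearest measured neighbour, compound 3, sits within the scatter of that number. Compound 3 `CN1CCN(CCCCOc2c(O)cc3oc(-c4ccccc4)cc(=O)c3c2O)CC1` carries hydrogen in place of methyl on an oxygen on an aromatic ring and gives 82900 nM in this assay; the step of a 1.5-fold higher number from compound 2 to compound 3 (0.19 log units; within the scatter) stays within the scatter. Compound 4 `COc1cc2oc(-c3ccccc3)cc(=O)c2c(O)c1OCCCN1CCN(C)CC1` differs from compound 2 by 4-methylpiperazin-1-yl in place of (4-methylpiperazin-1-yl)methyl on a saturated chain carbon, three bonds along the chain from an oxygen on an aromatic ring. For the measured compounds named here, no measured step in this set varies the chain that links the 4-methylpiperazin-1-yl group to the oxygen on the aromatic ring; the only measured step, a 1.5-fold higher number from compound 2 to compound 3 (0.19 log units; within the scatter), concerns a different position and was small. The shorter chain is therefore expected to move the number in this assay little, and the expected step of a 1.1-fold lower number from compound 2 to compound 4 (0.03 log units; within the scatter) is set at none beyond the scatter. Compound 4 is estimated at 50000 nM, with a range from 20000 nM to 150000 nM.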

Compound 4, half-maximal inhibitory concentration: 31300 nM
Beside the measured number, compound 4's estimate is 1.6-fold (0.20 log units) above it; measured number inside the range.
By their numbers in this assay, from the lowest: compounds 4, 2 and 3 (each within the scatter of the next, the first and the last beyond it). At a limit, above all of these: compound 1.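

Shortening the chain is now a measured change: in this assay, 4-methylpiperazin-1-yl in place of (4-methylpiperazin-1-yl)methyl on a saturated chain carbon gives a 1.7-fold lower number from compound 2 to compound 4 (0.23 log units; within the scatter). This position, so far untested, therefore takes this single shortening with no change beyond the scatter, so the two chain lengths cannot be ranked on this read-out. Compound 1 enters no step, as its value is a limit of the assay: the limit of > 100000 nM in this assay, at which 1 of the 4 values shown sits.

On these data alone, whether a 2-(4-methylpiperazin-1-yl)ethyl group or a longer chain would also stay within the scatter in this assay remains open, and a single shortening gives no trend with chain length. Also open, as far as these compounds go, are a morpholine or a dimethylamino group in place of 4-methylpiperazin-1-yl, and the same shortening on compound 3.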